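Adding a methoxy group to a benzofuran chalcone series

The source may report more compounds than this note shows. Statements on the series, on what has been measured and on what is new or still open speak of the compounds shown alone.

Measured compounds:
- compound 1, `COc1cc(OC)c(OC)cc1/C=C/C(=O)c1cc2ccoc2cc1O`: 13400 nM
- compound 2, `COc1ccc(/C=C/C(=O)c2cc3ccoc3cc2O)cc1OC`: 10800 nM
- compound 3, `COc1ccc(/C=C/C(=O)c2ccc3occc3c2O)cc1`: 9200 nM

Of the compounds shown here, three have been tested in an assay on isolated protein for inhibition of lysosomal alpha-glucosidase (Rattus norvegicus), read by spectrophotometry, with a stated time of 5 min; a higher number here means a weaker inhibitor, a lower number a stronger inhibitor. Compound 1 gives 13400 nM, compound 2 gives 10800 nM and compound 3 gives 9200 nM. All three numbers lie close together, and none of the gaps between them is beyond the scatter, so no order among them can be read from these data.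

Compound 2 and compound 1 differ in one place: methoxy in place of hydrogen on an aromatic carbon. The step of a 1.2-fold higher number from compound 2 to compound 1 (0.09 log units; within the scatter) is within the scatter. Compound 2 and compound 3 carry different cores; how the two cores differ is not broken down here.

Compound 4, `COc1ccc(/C=C/C(=O)c2ccc3occc3c2O)cc1OC`, has not been measured in this assay. It differs from compound 3 in one place: methoxy in place of hydrogen on an aromatic carbon. Among the measured compounds shown here, this is the same kind of change as the one from compound 2 to compound 1, but the place is not the same: in compound 4 the entering methoxy sits ortho to a methoxy group and meta to a large group, whereas in compound 1 it sits ortho to a large group, meta to a methoxy group and para to a methoxy group.

For the measured compounds named here, for compound 4 a step of about a 1.1-fold higher number from compound 3 to compound 4 (0.06 log units; within the scatter) is expected in this assay, resting on the single precedent a 1.2-fold higher number from compound 2 to compound 1 (0.09 log units; within the scatter), which showed essentially no movement. Compound 4 is therefore estimated to give 10500 nM, with a likely range from 5000 nM to 22000 nM.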

Compound 4, half-maximal inhibitory concentration: 5000 nM
Compound 4: middle estimate off by 2.1-fold (0.32 log units), on the high side; the range from low to high includes it.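

In this assay, methoxy in place of hydrogen on an aromatic carbon gives a 1.8-fold lower number from compound 3 to compound 4 (0.26 log units; within the scatter), so on this core, as on the other, the step stays inside the usual scatter of repeated measurements. Set side by side, the two steps cannot be told apart: the same change on two cores in this assay, a 1.2-fold higher number (0.09 log units; within the scatter) from compound 2 to compound 1 and a 1.8-fold lower number (0.26 log units; within the scatter) from compound 3 to compound 4, 2.3-fold (0.36 log units) apart, within the scatter of two such steps. Among the compounds shown here, this shows that in these two pairs the change has no effect that can be read on either core and that nothing here separates one core from the other, but it does not show that the change carries over reliably, as there are only two pairs, the entering methoxy stands in a different place in each, and small differences between the cores would go unseen.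

Methoxy is the only group that enters in a single change among the compounds shown, which leaves open how a halogen such as fluorine, an amine or a carboxylic acid would behave in the same places. On these data alone, it also remains open whether a longer chain such as ethoxy in place of methoxy, or the loss of the hydroxyl group on the core, would move the number beyond the scatter.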